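The compounds below may be only part of what the source reports. "The series", "measured", "known", "first", "only" and "open" are said of these compounds alone.

In a functional assay on L1210 cells (Mus musculus) for cytotoxicity, read by MTT assay, with a stated time of 48 h (on this read-out lower numbers stand for stronger inhibition and higher numbers for weaker inhibition), compound 1 `C=C1C(=O)O[C@@H](C)[C@@H]1c1ccc(Br)cc1` gives 580 nM, compound 2 `C=C1C(=O)O[C@@H](C)[C@@H]1c1ccc(OC)cc1` gives 1950 nM and compound 3 `C=C1C(=O)O[C@H](C)[C@@H]1c1ccc(C)cc1` gives 5500 nM. Compound 3 therefore has the highest number of the three and is the weakest so far, with both gaps beyond the scatter. Compound 4 `C=C1C(=O)O[C@@H](C)[C@@H]1c1ccc(C)cc1` differs from compound 3 only in configuration as drawn (the two compounds have the same atoms and bonds and differ only in configuration as drawn: 1 of 2 stereo elements differ; a stereocentre at a saturated ring carbon is drawn R in compound 3 and S in compound 4): a stereocentre at a saturated ring carbon is drawn R in compound 3 and S in compound 4.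

Among the compounds with values here, the one measured step, a 3.4-fold higher number from compound 1 to compound 2 (0.53 log units; beyond the scatter), is modest and beyond the scatter, but it replaces bromo with methoxy on an aromatic carbon and leaves the drawn configuration unchanged. Within the data shown here, no measured step isolates a change of configuration. Compound 1 and compound 2 do share the configuration drawn for compound 4, and both lie lower than compound 3, with compound 2 at 1950 nM the closer of the two. Their aromatic groups also differ from that of compound 3, so this comparison is only indirect. A modest move toward a lower number is expected, and the estimated step is a 2.5-fold lower number from compound 3 to compound 4 (0.40 log units; beyond the scatter). For compound 4 the estimated value is 2200 nM, with an expected range from 700 nM to 6500 nM.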

Compound 4, half-maximal inhibitory concentration: 1500 nM
Compound 4: middle estimate off by 1.5-fold (0.17 log units), on the high side, and the stated range covers the measured number.
By their numbers in this assay, from the lowest: compound 1; then compounds 4 and 2 (each within the scatter of the next); then compound 3.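

In this assay, within the data shown here, a 3.7-fold lower number from compound 3 to compound 4 (0.56 log units; beyond the scatter) is the first step that isolates configuration, and it shows that this stereocentre alone shifts the number beyond the scatter, with no group entering or leaving: the fact that compounds 3 and 4 differ only in the configuration as drawn. With the stereocentre drawn as in compound 4, methyl and methoxy on the aromatic carbon cannot be told apart, at a 1.3-fold lower number from compound 2 to compound 4 (0.11 log units; within the scatter), whereas bromo keeps a real edge, at a 2.6-fold higher number from compound 1 to compound 4 (0.41 log units; beyond the scatter). Methyl alone therefore does not set compound 3 apart, as compound 4 carries the same methyl and lies in the range of compound 2.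

The compounds shown leave open whether inverting this stereocentre gives a step of similar size with bromo or methoxy on the aromatic carbon, and what the other stereo element contributes. They also leave open how an amine or a carboxylic acid in place of methyl on that aromatic carbon would read in this assay.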